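Amide nitrogen substituent series: notes toward compound 4

The source may hold more compounds than are shown below. What is called first, only, known or untested is meant among the compounds shown, and "the series" means these compounds.

Measured so far in an assay on HEK293 cells for agonist activity at transient receptor potential cation channel subfamily M member 8 (Homo sapiens), read by fluorescence and calcium flux, with a stated time of 15 min; on this read-out higher numbers stand for an effect only at larger amounts of compound and lower numbers for an effect already at smaller amounts:
compound 1 `Cc1ccc(OCC(=O)N(CCO)Cc2cccs2)cc1` gives 900 nM
compound 2 `Cc1ccc(OCC(=O)N(Cc2cccs2)c2ccn[nH]2)cc1` gives 0.2 nM
compound 3 `Cc1ccc(OCC(=O)N(Cc2cccs2)c2nccn2C)cc1` gives 1790 nM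

Compound 3 carries the highest of the three numbers. Its nearest neighbour is compound 1, and the step of a 2.0-fold higher number from compound 1 to compound 3 (0.30 log units; within the scatter) lies within the scatter. Its furthest is compound 2, with the step of a 9000-fold higher number from compound 2 to compound 3 (3.95 log units; beyond the scatter), a large one.

Compound 4 `CCN(Cc1cccs1)C(=O)COc1ccc(C)cc1` is the next candidate for this assay. Change from compound 3: ethyl in place of 1-methyl-1H-imidazol-2-yl on an amide-type nitrogen.

Among the measured compounds shown here, of the measured steps, only the one from compound 1 to compound 3 bears on this, since it also trades a short chain against the same ring on the same nitrogen, and it stayed within the scatter. The steps involving compound 2 concern the 1H-pyrazol-5-yl and do not transfer to an ethyl. The expected step for compound 4 is therefore small, a 1.5-fold lower number from compound 3 to compound 4 (0.17 log units; within the scatter), with no direction beyond the scatter.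

Compound 4 is estimated at 1200 nM in this assay, expected between 300 nM and 5000 nM.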

Compound 4, half-maximal effective concentration: 8 nM
Estimate against measurement, compound 4: 150-fold (2.18 log units) above; the whole stated range lies above it.
By their numbers in this assay, from the lowest: compound 2; then compound 4; then compounds 1 and 3 (each within the scatter of the next).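

In this assay, a small change to the chain on the amide-type nitrogen matters greatly: hydrogen in place of hydroxy gives a 110-fold lower number from compound 1 to compound 4 (2.05 log units; beyond the scatter), so compound 1 and compound 4 are not interchangeable. A ring on this nitrogen is not required for a low number, as ethyl gives a 220-fold lower number from compound 3 to compound 4 (2.35 log units; beyond the scatter), yet 1H-pyrazol-5-yl remains ahead of ethyl (a 40-fold higher number from compound 2 to compound 4 (1.60 log units; beyond the scatter)). No evidence at hand accounts for these steps.

Open, from the compounds shown here alone, is whether a longer chain such as n-propyl, or an amine at the chain end, keeps the number of compound 4.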